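Bromo to Fluoro on the Aryl Ring of Compound 2

This account rests on a few compounds, and the source may have more. Where it says the series, first, only, none or still open, it means among the compounds named here.

Three compounds have results in an assay on HepG2 cells for agonist activity at nuclear receptor subfamily 1 group I member 3 (Homo sapiens), read by a luciferase reporter, with a stated time of 23 h; on this read-out higher numbers stand for an effect only at larger amounts of compound and lower numbers for an effect already at smaller amounts. Compound 2, `Clc1ccc(CO/N=C/c2c(-c3ccc(Br)cc3)nc3sccn23)cc1Cl`, gives 480 nM in this assay. Going by the values given here, compound 1, `FC(F)(F)c1ccc(CO/N=C/c2c(-c3ccc4ccccc4c3)nc3occn23)cc1`, gives 470 nM in this assay, a number that lies within the scatter of the one for compound 2, so the two cannot be ordered. Compound 3, `C(=N/OCc1ccc(Oc2ccccc2)cc1)\c1c(-c2ccc3ccccc3c2)nc2occn12`, was reported in this assay as "not active" (no number reported), with no number attached. No pair among these three differs in a single place, so no measured step is available to guide the next change.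

Compound 4, `Fc1ccc(-c2nc3sccn3c2/C=N/OCc2ccc(Cl)c(Cl)c2)cc1`, is still to be measured in this assay. It differs from compound 2 by fluoro in place of bromo on an aromatic carbon, one substituent exchanged for another on a six-membered aromatic ring of carbon only, para to a large group. Among the compounds with values here, nothing among the measured compounds shows what such an exchange does here. The expected step is a 1.7-fold higher number from compound 2 to compound 4 (0.22 log units; within the scatter), a modest shift toward a larger number, though a result within the scatter would not surprise. Compound 4 is therefore estimated at 800 nM in this assay, with a range from 300 nM to 2500 nM.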

Compound 4, half-maximal effective concentration: 670 nM
Estimate against measurement, compound 4: 1.2-fold (0.08 log units) above; the measured number falls inside the stated range.
By their numbers in this assay, from the lowest: compounds 1, 2 and 4 (each within the scatter of the next).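

Fluoro in place of bromo on the aromatic carbon para to a large group gives a 1.4-fold higher number from compound 2 to compound 4 (0.14 log units; within the scatter) in this assay, the only measured step among these compounds. The 4-bromophenyl to 4-fluorophenyl exchange therefore leaves compound 2 and compound 4 unresolved in this read-out, so this place accepts either halogen without a change that can be told from the scatter. Nothing measured here gives a reason for this result.

From the compounds shown here alone, whether an amine, a carboxylic acid or a longer chain at this place would keep the number in this assay remains open, since only these two halogens stand there in compound 2 and compound 4. Also open, going by these compounds, is whether the same exchange would give a comparable step on the core of compound 1.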